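Removing the Bromine from the Anilino Ring of Compound 2

A few compounds are considered here, and "the series" means these few. Any claim that something is new, unique, unknown or untested is made for them only; others in the source may bear on it.

Within the data shown here, compound 2 `O=C1C=C(Nc2ccc(Br)cc2)C(=O)c2c1nc1n2[C@H]2OC[C@@H](O)[C@H]2OC1` holds the lower of the two numbers so far in a functional assay on HeLa cells (Homo sapiens) for inhibition, read by sulforhodamine B assay (on this read-out higher numbers stand for weaker inhibition and lower numbers for stronger inhibition), where compound 2 gives 3830 nM; its only neighbour is compound 1 `O=C1C=C(Nc2ccccc2F)C(=O)c2c1nc1n2[C@H]2OC[C@@H](O)[C@H]2OC1`, which in this assay gives 5120 nM, and the step of a 1.3-fold lower number from compound 1 to compound 2 (0.13 log units; within the scatter) bears on the present case. Compound 3 `O=C1C=C(Nc2ccccc2)C(=O)c2c1nc1n2[C@H]2OC[C@@H](O)[C@H]2OC1` carries hydrogen in place of bromo on an aromatic carbon. Among the measured compounds shown here, since the one measured change of the substituent on this ring stayed within the scatter, no step beyond the scatter is expected. Compound 3 is therefore estimated at 4500 nM, between 2000 nM and 10000 nM. The expected step of a 1.2-fold higher number from compound 2 to compound 3 (0.07 log units; within the scatter) should stay within the scatter.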

Compound 3, half-maximal inhibitory concentration: 5620 nM
Compound 3: middle estimate off by 1.2-fold (0.10 log units), on the low side; measured number inside the range.
By their numbers in this assay, from the lowest: compounds 2, 1 and 3 (each within the scatter of the next).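

In this assay replacing the bromo group with hydrogen gives a 1.5-fold higher number from compound 2 to compound 3 (0.17 log units; within the scatter) and replacing the fluoro group with hydrogen gives a 1.1-fold higher number from compound 1 to compound 3 (0.04 log units; within the scatter) on the same anilino ring. With the unsubstituted ring of compound 3 now as a reference, neither halogen separates from hydrogen beyond the scatter. No evidence is available to account for how close these numbers lie.

The compounds shown leave open whether a group other than a halogen, such as an amine, a carboxylic acid or a methoxy group, would move the number beyond the scatter.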